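Methyl to Isopropyl on the Ring Nitrogen

The source may report more compounds than this note shows. Statements on the series, on what has been measured and on what is new or still open speak of the compounds shown alone.

Compound 3 `Cn1cc2c(Cl)nc(NC(=O)c3ccc(F)cc3)nc2n1` carries a fluoro on an aromatic carbon. In an assay on CHO cells for displacement of a labelled ligand from adenosine receptor A1 (Homo sapiens), read by scintillation counting, with a stated time of 3 h (on this read-out higher numbers stand for weaker inhibition and lower numbers for stronger inhibition), compound 3 returns only a limit, > 100000 nM. Its two neighbours fare the same way. Compound 1 `Cc1ccc(C(=O)Nc2nc(Cl)c3cn(C)nc3n2)cc1` gives a limit of > 100000 nM in this assay. Compound 2 `Cn1cc2c(Cl)nc(NC(=O)c3ccc(C(F)(F)F)cc3)nc2n1` likewise gives a limit of > 100000 nM. Hence the steps a step that the two limits leave unreadable from compound 1 to compound 2, a step that the two limits leave unreadable from compound 1 to compound 3 and a step that the two limits leave unreadable from compound 2 to compound 3 cannot be read in size, and all three values sit at the limit of > 100000 nM in this assay, at which 3 of the 3 values shown sit. Compound 4 `CC(C)n1cc2c(Cl)nc(NC(=O)c3ccc(F)cc3)nc2n1` differs from compound 3 in one place: isopropyl in place of methyl on an aromatic nitrogen. For the measured compounds named here, none of the measured steps touches that nitrogen, and none of them yields a readable size, so there is no measured ground for expecting a shift in this assay in either direction beyond the scatter. Compound 4 is therefore expected to give 100000 nM, within 30000 nM to 300000 nM. The step of a number no higher from compound 3 to compound 4 (the limit leaves the size open) is expected to be essentially none, with the value most likely again reported only as a limit.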

Compound 4, inhibition constant: 3400 nM
The estimate for compound 4 lay 29-fold (1.47 log units) above the measured number, and the stated range ends above it.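

The ring nitrogen proved to be a place where this series responds: in this assay, isopropyl in place of methyl gives an at least 29-fold lower number from compound 3 to compound 4 (1.46 log units; beyond the scatter), a step beyond the scatter. For the compounds shown here, the earlier changes, all on an aromatic carbon, could not be read, so this is the first evidence that any single change moves the read-out, and it does so towards stronger inhibition. Compound 4 is the only compound shown that gives a number rather than a limit: the limit of > 100000 nM in this assay, at which 3 of the 4 values shown sit.

The compounds shown do not tell whether an ethyl, a cyclopentyl or a longer chain such as n-butyl on that nitrogen would go further or fall back. They also leave open whether methyl or trifluoromethyl in place of the fluoro would change the number once isopropyl is on the ring nitrogen.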